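The source may hold more compounds than are shown below. What is called first, only, known or untested is meant among the compounds shown, and "the series" means these compounds.

Measured compounds:
compound 1, `COc1cc(-n2cccc2C(=O)N2CCCCC2)ccc1Nc1ncc(Cl)c(Nc2ccccc2NS(C)(=O)=O)n1` — 630 nM
compound 2, `CCN1CCN(C(=O)c2cccn2-c2ccc(Nc3ncc(Cl)c(Nc4ccccc4NS(C)(=O)=O)n3)c(OC)c2)CC1` — 1130 nM

In a functional assay on NCI-H2228 cells (Homo sapiens) for antiproliferative activity, read by MTT assay, with a stated time of 72 h (a higher number here means a weaker inhibitor, a lower number a stronger inhibitor), compound 1 gives 630 nM. Compound 2 gives 1130 nM in this assay. Compound 2 therefore carries the higher of the two numbers, but the only measured step, a 1.8-fold higher number from compound 1 to compound 2 (0.25 log units; within the scatter), stays within the scatter, so the two compounds cannot be told apart on the numbers shown.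

Compound 3, `COc1cc(-n2cccc2C(=O)N2CCCC2)ccc1Nc1ncc(Cl)c(Nc2ccccc2NS(C)(=O)=O)n1`, has not yet been measured in this assay. It differs from compound 2 in one place: pyrrolidin-1-yl in place of 4-ethylpiperazin-1-yl on a carbonyl carbon. Among the compounds with values here, the one measured step that bears on this position is a 1.8-fold higher number from compound 1 to compound 2 (0.25 log units; within the scatter), where the ring on the carbonyl carbon was also exchanged and the number hardly moved. Compound 3 brings a ring with one hetero atom and no hydrogen-bond acceptor back to that carbonyl carbon, which is closer to the situation of compound 1 than to that of compound 2. The expected step, a 1.6-fold lower number from compound 2 to compound 3 (0.21 log units; within the scatter), is therefore small, most likely a slightly lower number, and not beyond the scatter. Compound 3 is expected to give about 700 nM in this assay, with a likely range from 300 nM to 1800 nM.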

Compound 3, half-maximal inhibitory concentration: 600 nM
Compound 3: middle estimate off by 1.2-fold (0.07 log units), on the high side; the range from low to high includes it.
By their numbers in this assay, from the lowest: compounds 3, 1 and 2 (each within the scatter of the next).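

In this assay, the ring on the carbonyl carbon has now been exchanged in two further ways, and both steps stay within the scatter (a 1.9-fold lower number from compound 2 to compound 3 (0.27 log units; within the scatter); a 1.1-fold lower number from compound 1 to compound 3 (0.02 log units; within the scatter)). All three steps among these compounds are now available, and none of them separates any pair, so piperidin-1-yl, 4-ethylpiperazin-1-yl and pyrrolidin-1-yl cannot be told apart at this position on these numbers. That holds even for the exchange of 4-ethylpiperazin-1-yl, with 8 heavy atoms and 1 hydrogen-bond acceptor, for pyrrolidin-1-yl, with 5 heavy atoms and no hydrogen-bond acceptor, and nothing available explains this result.

Going by these compounds, all three groups are non-aromatic rings joined to the carbonyl carbon through a ring nitrogen, so it remains open whether an open-chain dimethylamino group, a morpholin-4-yl ring or a piperazine ring carrying a free amine would stay within the scatter as well. On these data alone, it is equally open whether replacing the whole amide with a carboxylic acid or a longer chain ending in an amine would produce a step beyond the scatter at this position.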